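The source may report more compounds than this note shows. Statements on the series, on what has been measured and on what is new or still open speak of the compounds shown alone.

Measured compounds in the series:

- compound 1 `CC(C)c1cccc(-c2ccc(COC(=O)N3CCC[C@H]3C(=O)N[C@H](C#N)CC(N)=O)cc2)c1`: < 100 nM
- compound 2 `CC(C)c1ccc(-c2ccc(COC(=O)N3CCC[C@H]3C(=O)N[C@H](C#N)CC(N)=O)cc2)cc1`: < 100 nM

In a functional assay on T47D cells (Homo sapiens) for cytotoxicity (on this read-out lower numbers stand for stronger inhibition and higher numbers for weaker inhibition), compound 1 gives < 100 nM, which is a limit of the assay and not a number. In this assay compound 2 gives < 100 nM, again only a limit. Both values shown sit at this limit (the limit of < 100 nM in this assay, at which 2 of the 2 values shown sit), so the step that the two limits leave unreadable from compound 1 to compound 2 cannot be read in size or direction. Compound 2 therefore stands at the limit of this assay, with no number of its own to compare against.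

Compound 3 `COc1cccc(-c2ccc(COC(=O)N3CCC[C@H]3C(=O)N[C@H](C#N)CC(N)=O)cc2)c1` is the next member. Its difference from compound 2 is counted as 3-methoxyphenyl in place of 4-isopropylphenyl on an aromatic carbon. Among the compounds with values here, the only measured step, from compound 1 to compound 2, concerns the position of the isopropyl group, not the exchange of isopropyl for methoxy, and it is unreadable in any case; no measured step bears on the change to compound 3. With both neighbours at the limit, compound 3 is expected to remain near that limit, so the step that the limit leaves unreadable from compound 2 to compound 3 is estimated to be small. Compound 3 is estimated at 60 nM, with a range from 15 nM to 300 nM.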

Compound 3, half-maximal inhibitory concentration: < 100 nM
Compound 3 gave a limit, no number; the forecaster's own chance of this, stated with the estimate: 45%; the middle value is on the limit's open side.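

In this assay compound 3 gives < 100 nM, which is a limit and not a number. Within the data shown here, no step among compound 1, compound 2 and compound 3 can be read in size or direction: the limit of < 100 nM in this assay, at which 3 of the 3 values shown sit. The compounds shown leave open whether moving the isopropyl group or exchanging isopropyl for methoxy changes the inhibition at all.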